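Dropping the methoxy from a piperidinyl dithiocarbamate chromone

The source may hold more compounds than are shown below. What is called first, only, known or untested is meant among the compounds shown, and "the series" means these compounds.

Of the compounds shown here, three built on a shared core have been measured, and a fourth has not. In a functional assay on HeLa cells (Homo sapiens) for antiproliferative activity, read by MTT assay, with a stated time of 72 h (a higher number here means a weaker inhibitor, a lower number a stronger inhibitor), compound 2 `COc1ccc2occ(CSC(=S)N3CCCC3)c(=O)c2c1` gives 12100 nM. Compound 3 `COc1ccc2occ(CSC(=S)N3CCCCC3)c(=O)c2c1` differs from it in that (piperidin-1-yl in place of pyrrolidin-1-yl on a thiocarbonyl carbon), and in this assay compound 3 gives 3500 nM, which is the lowest of the two numbers recorded. That change made a 3.5-fold lower number from compound 2 to compound 3 (0.54 log units; beyond the scatter). Compound 1 `O=c1c(CSC(=S)N2CCCC2)coc2ccccc12` differs from compound 2 in that (hydrogen in place of methoxy on an aromatic carbon). For compound 1 this assay reports > 25000 nM, and this is a limit of the assay rather than a number (the limit of > 25000 nM in this assay, at which 1 of the 3 values shown sits). The step that goes with it is an at least 2.0-fold higher number from compound 2 to compound 1 (0.31 log units; beyond the scatter).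

Compound 4 `O=c1c(CSC(=S)N2CCCCC2)coc2ccccc12` is the one still to be measured. It differs from compound 3 in that (hydrogen in place of methoxy on an aromatic carbon); the place is the same as the place of the change from compound 2 to compound 1, so this is the same change, now made on the core that carries the piperidin-1-yl group instead of the pyrrolidin-1-yl group. Within the data shown here, the only precedent for it is the step of an at least 2.0-fold higher number from compound 2 to compound 1 (0.31 log units; beyond the scatter), which gives a lower bound and not a full size, so the size expected here is uncertain. Compound 4 is expected to show a 3.4-fold higher number from compound 3 to compound 4 (0.54 log units; beyond the scatter) in this assay. Compound 4 is estimated at 12000 nM, with a range from 5000 nM to 30000 nM, and a real chance that this assay again reports only a limit.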

Compound 4, half-maximal inhibitory concentration: 2300 nM
Compound 4: the middle estimate sits 5.2-fold (0.72 log units) above what was measured; measured number outside the range, below it.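

In this assay, hydrogen in place of methoxy on the core carrying the piperidin-1-yl group comes to a 1.5-fold lower number from compound 3 to compound 4 (0.18 log units; within the scatter), so the rise in number seen with the pyrrolidin-1-yl group does not carry over to this core: the same change on two cores in this assay, an at least 2.0-fold higher number (0.31 log units; beyond the scatter) from compound 2 to compound 1 and a 1.5-fold lower number (0.18 log units; within the scatter) from compound 3 to compound 4, at least 3.1-fold (0.49 log units) apart, beyond the scatter of two such steps The other change depends on the core as well, since piperidin-1-yl in place of pyrrolidin-1-yl on the core without methoxy gives an at least 10-fold lower number from compound 1 to compound 4 (1.03 log units; beyond the scatter), which differs from the step on the methoxy core: the same change on two cores in this assay, a 3.5-fold lower number (0.54 log units; beyond the scatter) from compound 2 to compound 3 and an at least 10-fold lower number (1.03 log units; beyond the scatter) from compound 1 to compound 4, at least 3.1-fold (0.49 log units) apart, beyond the scatter of two such steps Compound 1 is recorded only as a limit of the assay, so the true size of both gaps stays unknown, and the data show that the two changes do not act independently here, not why they fail to: the limit of > 25000 nM in this assay, at which 1 of the 4 values shown sits.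

The compounds shown leave open how another amine on the thiocarbonyl carbon, such as morpholine or diethylamine, would behave, and whether a chlorine or a hydroxyl group in place of methoxy on that aromatic carbon would follow the pattern of the piperidin-1-yl pair or of the pyrrolidin-1-yl pair. They also leave open whether this dependence on the core extends to any pair beyond these four compounds in this assay.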